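Phenyl in Place of Methyl on the Aryl Ether Chain

The source may hold more compounds than are shown below. What is called first, only, known or untested is meant among the compounds shown, and "the series" means these compounds.

Within the data shown here, of the two compounds measured so far in an assay on brain for inhibition of Amine oxidase [flavin-containing] A (Rattus norvegicus) (a higher number here means a weaker inhibitor, a lower number a stronger inhibitor), compound 2 `CCOc1ccc(C2CNCCS2)cc1` stands lowest: compound 2 gives 2170 nM. Among the measured compounds shown here, its nearest neighbour, compound 1 `CCCOc1ccc(C2CNC(=O)CS2)cc1`, gives 8680 nM, a gap beyond the usual scatter; the two differ in more than one place, so their values show only that compound 2 is the stronger inhibitor of the pair and nothing about any single change. The unmeasured compound 3 `c1ccc(COc2ccc(C3CNCCS3)cc2)cc1` is reached from compound 2 by one change: phenyl in place of methyl on a saturated chain carbon bound to an oxygen on an aromatic ring. For the measured compounds named here, no measured pair shows what this change does in this assay, so its effect is open. The analyst expects a step of modest size, toward a lower number, not far beyond the scatter, and holds the chance of no change at all as real. For compound 3 she estimates 1000 nM in this assay, within a range from 200 nM to 5000 nM. The step that this estimate means is a 2.2-fold lower number from compound 2 to compound 3 (0.34 log units; beyond the scatter), an expectation and not a measurement.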

Compound 3, inhibition constant: 19000 nM
Estimate against measurement, compound 3: 19-fold (1.28 log units) below; measured number outside the range, above it.
By their numbers in this assay, from the lowest: compound 2; then compound 1; then compound 3.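

In this assay, among these compounds, the pair of compound 2 and compound 3 gives the first reading of this change: phenyl in place of methyl on a saturated chain carbon bound to an oxygen on an aromatic ring gives an 8.8-fold higher number from compound 2 to compound 3 (0.94 log units; beyond the scatter), and so a weaker inhibitor. This position is therefore not indifferent to what it carries, since a single change there moves the number beyond the scatter, even though neither the entering nor the leaving group has a hydrogen-bond donor, a hydrogen-bond acceptor or a net charge. Nothing available here explains why the phenyl group has this effect on the number.

From the compounds shown here alone, this single pair cannot tell whether the step belongs to the aromatic ring of the phenyl group or simply to a group larger than methyl, so it remains open whether a longer saturated chain, a cyclohexyl group or a phenyl group carrying a fluorine at this place would lie nearer compound 2 or compound 3. Going by these compounds, it also remains open whether the same change would give a step of similar size and direction on the core of compound 1.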